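Methyl on the phenyl ring: from compound 3 to compound 4

A few compounds are considered here, and "the series" means these few. Any claim that something is new, unique, unknown or untested is made for them only; others in the source may bear on it.

Compound 1, `COc1cc(NC(=O)c2csc(-c3c[nH]c4ccc(Br)cc34)n2)cc(OC)c1OC`, gives 55800 nM in a functional assay on HeLa cells (Homo sapiens) for cytotoxicity, read by MTT assay, with a stated time of 48 h, in the absence of a further agent; on this read-out higher numbers stand for weaker inhibition and lower numbers for stronger inhibition.
Compound 2, `O=C(Nc1ccccc1)c1csc(-c2cn(Cc3ccc(Cl)cc3)c3ccccc23)n1`, gives 24300 nM in this assay.
Compound 3, `O=C(Nc1ccccc1)c1csc(-c2c[nH]c3ccccc23)n1`, gives only a limit of the assay, > 100000 nM.

For the measured compounds named here, compound 3 stands at the edge of what this assay reports: its value is a limit, not a number, and it is the one value of the three that sits there (the limit of > 100000 nM in this assay, at which 1 of the 3 values shown sits). The unmeasured compound 4, `Cc1ccc(NC(=O)c2csc(-c3c[nH]c4ccccc34)n2)cc1`, differs from compound 3 by methyl in place of hydrogen on an aromatic carbon.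

Going by the values given here, only one measured step exists in the set, an at least 4.1-fold higher number from compound 2 to compound 3 (0.61 log units; beyond the scatter), and it concerns a change on an aromatic nitrogen, not the phenyl ring that is varied here. Compound 1 also differs from compound 3 in more than one place, so it gives no clean reading on the phenyl ring either. Among the compounds with values here, no measured step therefore bears on the change from compound 3 to compound 4.

With nothing to support a shift in either direction, the expectation is a step of no size beyond the scatter, a number no higher from compound 3 to compound 4 (the limit leaves the size open), so that compound 4 is expected to remain at or near the limit like compound 3. The estimate for compound 4 is 100000 nM, within a range of 40000 nM to 300000 nM, with a real chance that only a limit is reported again.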

Compound 4, half-maximal inhibitory concentration: > 100000 nM
Compound 4: no number, only a limit; the forecaster's own chance of this, stated with the estimate: 60%; the middle value sits exactly at the limit.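

Compound 3 and compound 4 both give only a limit in this assay, so the step between them cannot be read: the limit of > 100000 nM in this assay, at which 2 of the 4 values shown sit.

Going by these compounds, it remains open whether methyl in place of hydrogen on an aromatic carbon changes the read-out in a compound that gives a number, such as compound 2 at 24300 nM.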